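Chloro in Place of Fluoro: From Compound 2 to Compound 4

The compounds below may be only part of what the source reports. "The series", "measured", "known", "first", "only" and "open" are said of these compounds alone.

The series shares one core, carried by compound 1 `CC(C)n1c(/C=C2/C(=O)Nc3ccc(Br)cc32)nc2ccccc21`, compound 2 `CCn1c(/C=C2/C(=O)Nc3ccc(F)cc32)nc2ccccc21` and compound 3 `Cn1c(/C=C2/C(=O)Nc3ccc([N+](=O)[O-])cc32)nc2ccccc21`. In a functional assay on PC-3 cells (Homo sapiens) for cytotoxicity, read by MTT assay, with a stated time of 48 h (on this read-out higher numbers stand for weaker inhibition and lower numbers for stronger inhibition), compound 1 gives 10700 nM. Compound 2 reaches only > 50000 nM, which is a limit of this assay and not a number. Compound 3 likewise stops at > 50000 nM, again a limit rather than a number. Compound 2 thus stands at the limit of > 50000 nM in this assay, at which 2 of the 3 values shown sit; one further value shown shares that limit, and only compound 1 gives a number. Among the measured compounds shown here, no pair of measured compounds differs in a single place, so the size of no step between them can be stated. Compound 4 `CCn1c(/C=C2/C(=O)Nc3ccc(Cl)cc32)nc2ccccc21` has not yet been tested in this assay. It differs from compound 2 by chloro in place of fluoro on an aromatic carbon. For compound 4 a modest gain in potency relative to the limit is expected, a step of an at least 1.6-fold lower number from compound 2 to compound 4 (0.22 log units; that floor lies within the scatter), with a real chance that this assay again reports only a limit. The estimate for compound 4 is 30000 nM, with a range from 8000 nM to 50000 nM.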

Compound 4, half-maximal inhibitory concentration: > 50000 nM
Compound 4: only a limit was reported; the forecaster's own chance of this, stated with the estimate: 45%; at least 1.6-fold (0.22 log units) between middle value and limit.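

In this assay compound 4 gives > 50000 nM, which is a limit and not a number. Among the compounds shown here, compound 2 also stands at a limit, so no step from it to compound 4 can be read. The compounds shown leave open whether chloro in place of fluoro on an aromatic carbon changes potency at all.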